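A few compounds are considered here, and "the series" means these few. Any claim that something is new, unique, unknown or untested is made for them only; others in the source may bear on it.

In a physicochemical assay for lipophilicity, measured as octanol-water partition, at pH 7.4 (a higher number here means a more lipophilic compound, a lower number a more polar compound), three compounds sharing one core have been measured: compound 1 `Cc1ccc(Cn2c(=O)[nH]c3c(N)nc(C(F)(F)F)cc32)nn1` gives 1.1, compound 2 `Cc1nc(Cn2c(=O)[nH]c3c(N)nc(C(F)(F)F)cc32)co1` gives 1.7, and compound 3 `CN1CCN(c2ccc(Cn3c(=O)[nH]c4c(N)nc(C(F)(F)F)cc43)cn2)CC1` gives 1.8. Compound 3 cannot be told apart from compound 2, and both lie clearly above compound 1. Compound 4 `Nc1nc(C(F)(F)F)cc2c1[nH]c(=O)n2Cc1ccc(NCC2CC2)nc1` carries (cyclopropylmethyl)amino in place of 4-methylpiperazin-1-yl on an aromatic carbon. Going by the values given here, no measured step covers this exchange. Among the compounds with values here, the only step available, a number 0.60 log units higher from compound 1 to compound 2 (beyond the scatter), swaps different groups, so it serves just as a rough guide to size. Judging from the structural change, a step of similar size, upward, is expected, and the estimated change is a number 0.70 log units higher from compound 3 to compound 4 (beyond the scatter). Compound 4 is therefore expected at 2.5, within a range of 1.9 to 3.1.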

Compound 4, distribution coefficient: 3.2
Beside the measured number, compound 4's estimate is 0.70 log units below it; the measured number lies above the stated range.
By their numbers in this assay, from the lowest: compound 1; then compounds 2 and 3 (each within the scatter of the next); then compound 4.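

In this assay the exchange at this aromatic carbon gives a number 1.40 log units higher from compound 3 to compound 4 (beyond the scatter), so a change at this one place can move the number a long way. The rise comes even though (cyclopropylmethyl)amino has fewer heavy atoms than 4-methylpiperazin-1-yl and brings 1 hydrogen-bond donor where the departing group has 0. Nothing available here explains this rise.

Which part of the exchange carries the step stays open, whether the loss of 4-methylpiperazin-1-yl, the amine hydrogen or the cyclopropyl ring. Piperidin-1-yl or cyclopropylmethoxy on the same carbon would help separate these parts.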